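Hydroxy Added to the Chain of Compound 2

The source may report more compounds than this note shows. Statements on the series, on what has been measured and on what is new or still open speak of the compounds shown alone.

The measured compounds: compound 1 `O=C(/C=C/C1CCCCC1)CC(O)C1CCCCC1`, which in a functional assay on WiDr cells (Homo sapiens) for antiproliferative activity, read by sulforhodamine B assay, with a stated time of 48 h (on this read-out lower numbers stand for stronger inhibition of growth and higher numbers for weaker inhibition of growth), gives 2900 nM. Compound 2 `C/C(=C\CC(C)C)C(=O)c1ccccc1` gives > 100000 nM, which is a limit of the assay and not a number. Compound 2 therefore stands at the limit of > 100000 nM in this assay, at which 1 of the 2 values shown sits. Compound 3 `CC(C)C/C=C(\CO)C(=O)c1ccccc1` is not yet measured; it differs from compound 2 by hydroxy in place of hydrogen on a saturated chain carbon bound to a double-bonded chain carbon. Among the compounds with values here, no measured step between two compounds exists here, and the value of compound 2 is a limit. The step expected in this assay is an at least 2.5-fold lower number from compound 2 to compound 3 (0.39 log units; beyond the scatter), a modest move toward stronger inhibition. Compound 3 is estimated at 40000 nM, with a range from 8000 nM to 200000 nM.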

Compound 3, concentration for 50% growth inhibition: 19000 nM
Beside the measured number, compound 3's estimate is 2.1-fold (0.32 log units) above it; low and high end bracket the measured number.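

In this assay, hydroxy in place of hydrogen on a saturated chain carbon bound to a double-bonded chain carbon gives an at least 5.2-fold lower number from compound 2 to compound 3 (0.72 log units; beyond the scatter), so this position responds to a single added oxygen, which compound 1 and compound 2 alone could not show. The true size of the step stays unknown, since compound 2 stands at a limit and not at a number: the limit of > 100000 nM in this assay, at which 1 of the 3 values shown sits.

Whether the hydroxy itself is needed remains open, as the compounds shown do not tell how a methoxy, an amine or a carboxylic acid would compare there. Also open, on these data alone, is whether a longer chain carrying the hydroxy would do the same.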